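This account rests on a few compounds, and the source may have more. Where it says the series, first, only, none or still open, it means among the compounds named here.

Compound 1 `Cc1ccc2[nH]c(C(=O)N[C@H]3CN(S(=O)(=O)c4ccccc4)C[C@@H]3C(=O)NC[C@H]3CCCN3)cc2c1`: 94%
Compound 2 `Cc1ccc2[nH]c(C(=O)N[C@H]3CN(S(=O)(=O)c4ccccc4)C[C@@H]3C(=O)NC[C@H]3CCCN3C)cc2c1`: 98%
Compound 3 `Cc1ccc2[nH]c(C(=O)N[C@H]3CCN(S(=O)(=O)c4ccccc4Cl)C[C@@H]3C(=O)N[C@H]3CCCN(C)C3)cc2c1`: 107%

In a functional assay on HEK293 cells for agonist activity at growth hormone secretagogue receptor type 1 (Homo sapiens), read by HTRF and inositol phosphate accumulation, with a stated time of 90 min, in the presence of a further agent that is not named here (on this read-out lower numbers stand for smaller maximal responses and higher numbers for larger maximal responses), compound 2 gives 98% and compound 1 gives 94%. The two differ by hydrogen in place of methyl on an amine nitrogen in a ring and the step is a number 4 percentage points lower from compound 2 to compound 1 (within the scatter). Compound 3, which gives 107% in this assay, carries a core whose difference from compound 2 is not broken down here. Compound 4 `Cc1ccc2[nH]c(C(=O)N[C@H]3CCN(S(=O)(=O)c4ccccc4Cl)C[C@@H]3C(=O)N[C@H]3CCCNC3)cc2c1` has not yet been measured; it differs from compound 3 by hydrogen in place of methyl on an amine nitrogen in a ring. This is the same kind of change as that from compound 2 to compound 1, not the same: there the place was a five-membered non-aromatic ring with 1 nitrogen, next to the ring atom that bears a large group, here a six-membered non-aromatic ring with 1 nitrogen, two ring bonds from the ring atom that bears a large group. Because the earlier step was a number 4 percentage points lower from compound 2 to compound 1 (within the scatter), the step for compound 4 is expected to be a number 4 percentage points lower from compound 3 to compound 4 (within the scatter). Compound 4 is therefore estimated to give 103% in this assay, between 90% and 115%.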

Compound 4, largest response reached (Emax), in percent of the reference or control that the assay uses: 97%
The estimate for compound 4 lay 6 percentage points above the measured number; measured number inside the range.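

In this assay, replacing 1-methylpiperidin-3-yl with piperidin-3-yl gives a number 10 percentage points lower from compound 3 to compound 4 (within the scatter) on the core of compound 3. Set beside the earlier step, hydrogen in place of methyl on an amine nitrogen in a ring carries across these two cores without a discernible difference: the same change on two cores in this assay, a number 4 percentage points lower (within the scatter) from compound 2 to compound 1 and a number 10 percentage points lower (within the scatter) from compound 3 to compound 4, 6 percentage points apart, within the scatter of two such steps. For the compounds shown here, this shows only that the change stays within the scatter on these two cores, even though the ring bearing the amine and its place differ, and it does not show that the step would be the same on any other core.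

The compounds shown leave open what an ethyl group or an acetyl group on that ring nitrogen would give on either core. They also leave open whether an amine in a seven-membered ring would behave in the same way.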